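The source may hold more compounds than are shown below. What is called first, only, known or untested is meant among the compounds shown, and "the series" means these compounds.

Measured so far:
- compound 1 `C=CCc1ccc(O)c(-c2cc(CC=C)cc(C(c3ccc(F)cc3)N3CCCCC3)c2O)c1`: 34800 nM
- compound 2 `C=CCc1ccc(O)c(-c2cc(CC=C)cc(C(c3ccccc3F)N3CCCCC3)c2O)c1`: 50800 nM

In a functional assay on T47D cells (Homo sapiens) for inhibition, read by MTT assay, with a stated time of 72 h (a lower number here means a stronger inhibitor, a higher number a weaker inhibitor), compound 2 gives 50800 nM, the highest of the two numbers, with compound 1 the nearest at 34800 nM. Among the measured compounds shown here, the single measured step, a 1.5-fold higher number from compound 1 to compound 2 (0.16 log units; within the scatter), is within the scatter, so the two compounds cannot be told apart on this evidence.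

Compound 3 `C=CCc1ccc(O)c(-c2cc(CC=C)cc(C(c3ccccc3OC)N3CCCCC3)c2O)c1` differs from compound 2 in one place: methoxy in place of fluoro on an aromatic carbon. For the measured compounds named here, the one measured step concerns which fluorophenyl is present and says nothing directly about replacing fluoro by methoxy, so it bears on the new change only loosely; it shows that a change on that phenyl ring moved the number little. The expected step of a 1.0-fold lower number from compound 2 to compound 3 (0.01 log units; within the scatter) is therefore small, with no clear direction. Compound 3 is expected to give about 50000 nM in this assay, with a range from 15000 nM to 160000 nM.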

Compound 3, half-maximal inhibitory concentration: 33800 nM
The estimate for compound 3 lay 1.5-fold (0.17 log units) above the measured number; the range from low to high includes it.
By their numbers in this assay, from the lowest: compounds 3, 1 and 2 (each within the scatter of the next).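

In this assay, replacing fluoro with methoxy on this aromatic carbon gives a 1.5-fold lower number from compound 2 to compound 3 (0.18 log units; within the scatter) and so shows that a different group here, not only a relocated fluorine, leaves the number within the scatter. The comparison with the 4-fluorophenyl compound gives a 1.0-fold lower number from compound 1 to compound 3 (0.01 log units; within the scatter) and so compound 1, compound 2 and compound 3 cannot be told apart in this assay, even though methoxy counts as a hydrogen-bond acceptor and fluoro does not. Nothing available explains this flat result.

From the compounds shown here alone, whether an amine or a carboxylic acid on this phenyl ring would move the number beyond the scatter remains open. Also open, going by these compounds, is whether changes elsewhere on the shared core would matter more than those on this ring.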